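The source may hold more compounds than are shown below. What is called first, only, known or untested is meant among the compounds shown, and "the series" means these compounds.

Compound 1 `CCCCCCCCc1ccc(OCC(=O)Cn2cnc3ccccc32)cc1`: 480 nM in an assay on microsomes from brain for inhibition of Fatty-acid amide hydrolase 1 (Rattus norvegicus), read by fluorescence and HPLC, with a stated time of 60 min; a higher number here means a weaker inhibitor, a lower number a stronger inhibitor 
Compound 2 `CCCCCCCCc1ccc(OCC(=O)Cn2cnc3cccnc32)cc1`: 410 nM 
Compound 3 `CCCCCCCCc1ccc(OCC(=O)Cn2nnc3cccnc32)cc1`: 13 nM 

Among these three, compound 3 gives the lowest number in this assay, and both of its steps are large and beyond the scatter: a 37-fold lower number from compound 1 to compound 3 (1.57 log units; beyond the scatter) and a 32-fold lower number from compound 2 to compound 3 (1.50 log units; beyond the scatter). The step between the other two, a 1.2-fold lower number from compound 1 to compound 2 (0.07 log units; within the scatter), stays within the scatter.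

Compound 4 `CCCCCCCCc1ccc(OCC(=O)Cn2nccn2)cc1` differs from compound 3 in one place: a group of 5 heavy atoms (2 carbon, 3 nitrogen; one five-membered aromatic ring with 3 hetero atoms) in place of a group of 9 heavy atoms (5 carbon, 4 nitrogen; one five-membered aromatic ring with 3 hetero atoms, one six-membered aromatic ring with 1 hetero atom), on a saturated chain carbon bound to a carbonyl carbon. Every measured step changed the group at this same position, and two of them were large, so this position clearly matters to the read-out. Nothing measured here shows what the smaller ring alone does. The expectation for compound 4 is therefore a weaker inhibitor, with a step of a 12-fold higher number from compound 3 to compound 4 (1.06 log units; beyond the scatter), and an estimated value of 150 nM (range 30 nM to 800 nM).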

Compound 4, half-maximal inhibitory concentration: 100 nM
Beside the measured number, compound 4's estimate is 1.5-fold (0.18 log units) above it; the range from low to high includes it.
By their numbers in this assay, from the lowest: compound 3; then compound 4; then compounds 2 and 1 (each within the scatter of the next).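

The single ring 2H-1,2,3-triazol-2-yl keeps much of the effect without the second ring: removing that ring gives a 7.7-fold higher number from compound 3 to compound 4 (0.89 log units; beyond the scatter). The smaller group still beats both larger groups whose five-membered ring has fewer hetero atoms, with a 4.1-fold lower number from compound 2 to compound 4 (0.61 log units; beyond the scatter) and a 4.8-fold lower number from compound 1 to compound 4 (0.68 log units; beyond the scatter). So across these four compounds, the two with three hetero atoms in the five-membered ring give the lowest numbers, and nothing available here explains this trend. From the compounds shown here alone, it remains open what a tetrazole ring or an amine would do at this position.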